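The source may hold more compounds than are shown below. What is called first, only, known or untested is meant among the compounds shown, and "the series" means these compounds.

Measured so far in an ADME assay on MCF-10A cells (Homo sapiens) for cytotoxicity, read by MTT assay, with a stated time of 72 h; a lower number here means a stronger inhibitor, a higher number a weaker inhibitor:

compound 1 `COc1ccc(-c2ccc(C)n2-c2ccc(-c3nc4ccc(F)cc4s3)cc2)cc1` — 37800 nM
compound 2 `COc1cc(-c2ccc(C)n2-c2ccc(-c3nc4ccc(F)cc4s3)cc2)cc(OC)c1OC` — 40000 nM
compound 3 `COc1ccc(-c2ccc(C)n2-c2ccc(-c3nc4ccc(OC)cc4s3)cc2)cc1` — 30600 nM

All three numbers lie close together; compound 2 sits within the scatter of compound 1 and compound 3 in this assay, so no order among them is claimed. Compound 3 differs from compound 1 by methoxy in place of fluoro on an aromatic carbon, and that change gave a 1.2-fold lower number from compound 1 to compound 3 (0.09 log units; within the scatter). The difference between the core of compound 2 and the core of compound 1 is not broken down here.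

Compound 4 `COc1ccc2nc(-c3ccc(-n4c(C)ccc4-c4cc(OC)c(OC)c(OC)c4)cc3)sc2c1` is not yet measured. It differs from compound 2 by methoxy in place of fluoro on an aromatic carbon, the same change made from compound 1 to compound 3, at a place described in the same words. For the measured compounds named here, since the one measured instance of this change moved the number only within the scatter, the expected step is a 1.2-fold lower number from compound 2 to compound 4 (0.08 log units; within the scatter) in this assay, resting on compound 2 with 40000 nM and on the earlier step of a 1.2-fold lower number from compound 1 to compound 3 (0.09 log units; within the scatter). Compound 4 is therefore estimated at 33000 nM, with a likely range from 20000 nM to 55000 nM; the estimate rests on a single precedent and should be treated as loose.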

Compound 4, half-maximal inhibitory concentration: 37800 nM
Compound 4: middle estimate off by 1.1-fold (0.06 log units), on the low side, within the range that was stated.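

In this assay the swap of fluoro for methoxy on an aromatic carbon gives a 1.1-fold lower number from compound 2 to compound 4 (0.02 log units; within the scatter) on the core of compound 2, so the second instance of this change also stays small. Set beside the first instance, the change behaves alike on the two cores, with no difference that can be told apart: the same change on two cores in this assay, a 1.2-fold lower number (0.09 log units; within the scatter) from compound 1 to compound 3 and a 1.1-fold lower number (0.02 log units; within the scatter) from compound 2 to compound 4, 1.2-fold (0.07 log units) apart, within the scatter of two such steps. For the compounds shown here, this shows only that on these two cores the step cannot be separated from the scatter; it does not show that the change has no effect on any other core or in any other assay, and a small dependence on the core would go unseen at this size of step.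

Still open, on these data alone, is whether a group other than fluoro or methoxy at this place, such as an amine, a carboxylic acid or a longer alkoxy chain, would move the number beyond the scatter. Also open, as far as these compounds go, is whether any change elsewhere on the shared core would do so.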